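The source may hold more compounds than are shown below. What is called first, only, known or untested is meant among the compounds shown, and "the series" means these compounds.

Series of bis-benzylidene cyclohexanones bearing one nitrophenyl arm, read in a functional assay on L1210 cells (Mus musculus) for cytotoxicity, with a stated time of 48 h; on this read-out lower numbers stand for stronger inhibition and higher numbers for weaker inhibition. Compound 1 `COc1cc(/C=C2\CCC/C(=C\c3ccccc3[N+](=O)[O-])C2=O)cc(OC)c1OC` gives 1520 nM, compound 2 `Cc1ccc(/C=C2\CCC/C(=C\c3ccccc3[N+](=O)[O-])C2=O)cc1` gives 7770 nM, and compound 3 `COc1cc(/C=C2\CCC/C(=C\c3cccc([N+](=O)[O-])c3)C2=O)cc(OC)c1OC` gives 42200 nM. Compound 3 stands at the highest number of the three; its nearest neighbour is compound 2 and its furthest is compound 1. Within the data shown here, the only single-point step among the measured compounds is a 28-fold higher number from compound 1 to compound 3 (1.44 log units; beyond the scatter), a large loss on moving the nitro group from one position of the ring to another.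

Compound 4 `COc1cc(/C=C2\CCC/C(=C\c3ccc([N+](=O)[O-])cc3)C2=O)cc(OC)c1OC` differs from compound 3 in one place: 4-nitrophenyl in place of 3-nitrophenyl on a double-bonded chain carbon bound to a double-bonded ring carbon. Among the measured compounds shown here, no measured step repositions the nitro group in this particular way, so the step from compound 1 to compound 3 is the only indirect guide; it shows that the placement of the nitro group can move this assay a long way, but it does not tell in which direction a further shift will go. The working expectation for compound 4 is therefore a step of a 2.1-fold lower number from compound 3 to compound 4 (0.32 log units; beyond the scatter) in this assay, small and uncertain, with a wide allowance on either side. The estimate for compound 4 in this assay is 20000 nM, ranging from 5000 nM to 80000 nM.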

Compound 4, half-maximal inhibitory concentration: 6970 nM
For compound 4 the middle estimate is 2.9-fold (0.46 log units) above the measured one, within the range that was stated.
By their numbers in this assay, from the lowest: compound 1; then compounds 4 and 2 (each within the scatter of the next); then compound 3.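

In this assay, the place on a double-bonded chain carbon bound to a double-bonded ring carbon now carries all three nitrophenyl groups on the same remainder of the molecule, and the response to moving the nitro group does not run steadily in one direction: a 6.1-fold lower number from compound 3 to compound 4 (0.78 log units; beyond the scatter) takes back a good part of the earlier loss, while a 4.6-fold higher number from compound 1 to compound 4 (0.66 log units; beyond the scatter) leaves 4-nitrophenyl short of 2-nitrophenyl. Among compound 1, compound 3 and compound 4, the large loss therefore belongs to 3-nitrophenyl rather than to every move away from 2-nitrophenyl, with 2-nitrophenyl giving the lowest number and each gap beyond the scatter. No measurement at hand accounts for this order.

From the compounds shown here alone, the arm carried by compound 2 appears here only with 2-nitrophenyl, so whether the same order of nitro positions holds with that arm remains open. Also open, going by these compounds, is whether the nitro group itself is needed at this place, or whether an amine, a nitrile or a carboxylic acid on the phenyl ring would give comparable numbers in this assay on this core.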